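Swapping a hydrogen for chlorine on the phenyl ring

The compounds below may be only part of what the source reports. "The series", "measured", "known", "first", "only" and "open" are said of these compounds alone.

Of the compounds shown here, two that share a core have been tested in a functional assay on the whole organism with Mus musculus as the target; a lower number here means that less compound is needed, a higher number that more compound is needed for the effect. Compound 1, `Cc1ccc2oc(=O)n(CCN3CCN(c4ccccc4)CC3)c2n1`, and compound 2, `O=c1oc2cccnc2n1CN1CCN(c2ccccc2)CC1`, both carry a phenylpiperazine on a tether, though the cores and tethers differ. In this assay compound 1 gives > 50 mg/kg, which is a limit of the assay rather than a measured number. In this assay, for the measured compounds named here, compound 2 gives 5.9 mg/kg, the only real number among the two values so far; the other sits at the limit of > 50 mg/kg in this assay, at which 1 of the 2 values shown sits. Compound 3, `O=c1oc2cccnc2n1CN1CCN(c2ccccc2Cl)CC1`, keeps everything in compound 2 and changes one spot: chloro in place of hydrogen on an aromatic carbon, so that the phenyl becomes a 2-chlorophenyl, with the chlorine placed on an aromatic carbon of the six-membered carbon ring, ortho to a large group. Going by the values given here, no measured pair in this set isolates such a change, so its effect cannot be read off from the data. The step from compound 2 to compound 3 is therefore expected to be small, most likely no larger than the usual run-to-run scatter, as a 1.0-fold higher number from compound 2 to compound 3 (0.01 log units; within the scatter) states. Compound 3 is accordingly expected to give about 6 mg/kg in this assay, within a range of 2 mg/kg to 20 mg/kg.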

Compound 3, dose for half-maximal effect: 22.2 mg/kg
Compound 3: middle estimate off by 3.7-fold (0.57 log units), on the low side; measured number above the stated range.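

For the compounds shown here, this is the first pair in the set that differs in only one place, so it gives the first direct reading of a change on the phenyl ring. In this assay, chloro in place of hydrogen on an aromatic carbon, ortho to a large group, gives a 3.8-fold higher number from compound 2 to compound 3 (0.58 log units; beyond the scatter), which means that more compound is needed for the same effect and that this position of the ring is not indifferent to what sits on it. A single added heavy atom is thus enough to produce a step larger than the usual scatter, although nothing measured here bears on why the chlorine has this effect.

The result rests on one pair and one substituent at one position, so it cannot yet be said whether the step comes from chlorine in particular or would also appear with a fluorine, a methyl or a methoxy group at the same place. From the compounds shown here alone, it also remains open whether a chlorine elsewhere on the phenyl ring, or the same 2-chlorophenyl on the longer tether and methylated core of compound 1, would shift the number in the same direction.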